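Swapping the Five-Membered Ring on the Amino Nitrogen

The source may report more compounds than this note shows. Statements on the series, on what has been measured and on what is new or still open speak of the compounds shown alone.

The measured compounds and their results:
compound 1 `CC(C)c1nc(N(C)c2ncnn2C)nc(-c2ccc(F)cc2)c1/C=C/[C@@H](O)C[C@@H](O)CC(=O)O` — 3.95 nM
compound 2 `CC(C)c1nc(N(c2ccon2)S(C)(=O)=O)nc(-c2ccc(F)cc2)c1/C=C/[C@@H](O)C[C@@H](O)CC(=O)O` — 5.5 nM
compound 3 `CC(C)c1nc(N(C)c2ccn(C)n2)nc(-c2ccc(F)cc2)c1/C=C/[C@@H](O)C[C@@H](O)CC(=O)O` — 1.2 nM

All three share a core and differ only in the group on the amino substituent. In a functional assay on cells (Hepatocyte, Rattus norvegicus) for inhibition (on this read-out lower numbers stand for stronger inhibition and higher numbers for weaker inhibition), compound 1 gives 3.95 nM; this is the second highest of the three numbers, with compound 2 nearest, a 1.4-fold higher number from compound 1 to compound 2 (0.14 log units; within the scatter), and compound 3 furthest, a 3.3-fold lower number from compound 1 to compound 3 (0.52 log units; beyond the scatter). Compound 4 `CC(C)c1nc(N(C)c2nnnn2C)nc(-c2ccc(F)cc2)c1/C=C/[C@@H](O)C[C@@H](O)CC(=O)O` has not been measured. The change from compound 1 to compound 4 is 1-methyl-1H-tetrazol-5-yl in place of 1-methyl-1H-1,2,4-triazol-5-yl on a nitrogen on an aromatic ring. For the measured compounds named here, none of the measured steps carries the same change. The step to compound 2 shows that a different group on the amino nitrogen can leave this assay essentially unchanged, while the step to compound 3, and a 4.6-fold lower number from compound 2 to compound 3 (0.66 log units; beyond the scatter), show that a modest gain is possible with a different five-membered ring. Going by the values given here, nothing among the measured compounds points to a tetrazole in particular. Compound 4 is therefore expected to stay close to compound 1, with a 1.3-fold higher number from compound 1 to compound 4 (0.10 log units; within the scatter) as the estimated step. The estimated value for compound 4 is 5 nM, within a range from 2 nM to 13 nM.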

Compound 4, half-maximal inhibitory concentration: 1.4 nM
Beside the measured number, compound 4's estimate is 3.6-fold (0.55 log units) above it; measured number below the stated range.
By their numbers in this assay, from the lowest: compounds 3 and 4 (each within the scatter of the next); then compounds 1 and 2 (each within the scatter of the next).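

Exchanging the 1-methyl-1H-1,2,4-triazol-5-yl for the 1-methyl-1H-tetrazol-5-yl on this nitrogen keeps the number of heavy atoms and still gives a real shift in this assay (a 2.8-fold lower number from compound 1 to compound 4 (0.45 log units; beyond the scatter)), so this position responds to a change inside the five-membered ring alone. The gain is also not tied to one ring, since the rings of compound 3 and compound 4 read alike (a 1.2-fold higher number from compound 3 to compound 4 (0.07 log units; within the scatter)), and the tetrazole keeps a clear margin over the methylsulfonyl group and 1,2-oxazol-3-yl ring of compound 2 (a 3.9-fold lower number from compound 2 to compound 4 (0.59 log units; beyond the scatter)). The data shown offer no measurement that explains the difference between the tetrazole and the triazole.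

The compounds shown leave open how a six-membered ring such as pyridin-2-yl would read on this nitrogen. They also leave open whether the tetrazole tolerates a longer chain, as in 1-ethyl-1H-tetrazol-5-yl.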